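Stereoinversion within a peroxide-tetrahydrofuran acid series

This account rests on a few compounds, and the source may have more. Where it says the series, first, only, none or still open, it means among the compounds named here.

Three members of this series have been tested in a functional assay on DU-145 cells (Homo sapiens) for cytotoxicity; a higher number here means a weaker inhibitor, a lower number a stronger inhibitor. Compound 1, `C=CCC/C=C\C=C/CCCCCCCC[C@@H]1CC[C@@H]([C@@H]2CC[C@@H](CC(=O)OC)OO2)O1`, gives 0.1 ug/mL in this assay. Compound 2, `C=CCCC/C=C/C=C\CCCCCCCC[C@@H]1CC[C@@H]([C@@H]2CC[C@@H](CC(=O)O)OO2)O1`, gives 0.1 ug/mL in this assay. Compound 3, `C=CCC/C=C\C=C/CCCCCCCC[C@H]1CC[C@@H]([C@@H]2CC[C@@H](CC(=O)O)OO2)O1`, gives 0.1 ug/mL in this assay. On the digits reported, compound 2 stands level with compound 1 and with compound 3; none of the gaps between them exceeds the usual scatter, so no ordering among the three can be drawn from these numbers.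

The next compound to be run is compound 4, `C=CCCC/C=C/C=C\CCCCCCCC[C@H]1CC[C@@H]([C@H]2CC[C@@H](CC(=O)O)OO2)O1`. It differs from compound 2 as follows: the two compounds have the same atoms and bonds and differ only in configuration as drawn: 2 of 6 stereo elements differ; a stereocentre at a saturated ring carbon is drawn R in compound 2 and S in compound 4; a stereocentre at a saturated ring carbon is drawn S in compound 2 and R in compound 4. Among the measured compounds shown here, no pair of measured compounds differs in exactly one place, so there is no measured step to lean on; the only guide is that the three measured compounds, which differ among themselves in configuration and in the terminal acid or ester, all sit at the same value in this assay.

Expectation for compound 4 is therefore a step of no size beyond the scatter, no change at the digits printed from compound 2 to compound 4 (within the scatter), in either direction. Compound 4 is expected to give about 0.1 ug/mL in this assay, estimated to fall between 0.05 ug/mL and 0.25 ug/mL.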

Compound 4, half-maximal inhibitory concentration: 0.1 ug/mL
Compound 4: the middle estimate sits on the measured number at the digits printed; measured number inside the range.
By their numbers in this assay, from the lowest: compounds 1, 2, 3 and 4 (each within the scatter of the next).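

Among the compounds shown here, compounds 2 and 4 form the first pair that can be read as a single comparison, and that comparison isolates configuration: the fact that compounds 2 and 4 differ only in the configuration as drawn. In this assay the result is no change at the digits printed from compound 2 to compound 4 (within the scatter), so exchanging the drawn configuration at two saturated ring carbons together, one from R to S and the other from S to R, gives no readable shift at this level of potency. The earlier compounds shown here could only suggest such tolerance, as they differ among themselves in more than one place, whereas here the atoms and bonds are held constant and the comparison rests on configuration alone.

The pair changes both stereocentres at once, so the effect of each alone stays unresolved, and these numbers cannot exclude two opposing contributions that cancel. The terminal end also remains open: the compounds shown carry only the acid and its methyl ester there, so an amide or a primary alcohol in that place has no value to go on, and neither does a shorter chain.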